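The source may hold more compounds than are shown below. What is called first, only, known or untested is meant among the compounds shown, and "the series" means these compounds.

In a functional assay on HCT-116 cells (Homo sapiens) for antiproliferative activity, read by CellTiter-Glo, with a stated time of 72 h (on this read-out higher numbers stand for weaker inhibition and lower numbers for stronger inhibition), compound 1 `Cc1ccc(-c2cc(/C=C/c3ccc(C(=O)NO)cc3)ccn2)cc1` gives 2390 nM, and compound 2 `Cc1ccc(-c2cc(/C=C/c3ccc(C(=O)NO)cc3)ccn2)c(F)c1` gives 800 nM. Compound 3 `Cc1ccc(-c2cc(/C=C/c3ccc(C(=O)NO)cc3)c(F)cn2)cc1` reads > 10000 nM, which is a limit of the assay and not a number. Compound 4 `Cc1ccc(-c2cc(/C=C/c3ccc(C(=O)NO)cc3)c(F)cn2)c(F)c1` differs from compound 3 by one change, fluoro in place of hydrogen on an aromatic carbon, turning 4-methylphenyl into 2-fluoro-4-methylphenyl.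

Among the measured compounds shown here, two measured steps bear on this. The closer one is the same change on the 4-methylphenyl group, seen as a 3.0-fold lower number from compound 1 to compound 2 (0.48 log units; beyond the scatter), a modest step beyond the scatter. The other, an at least 4.1-fold higher number from compound 1 to compound 3 (0.62 log units; beyond the scatter), puts a fluoro at a different place, and compound 3 already carries it. That step went the opposite way, so the shared core may stay weak in this assay.

A modest move toward lower numbers is therefore expected, although its starting point is known only as a limit, and compound 4 could also end up at that limit. The expected change is an at least 2.0-fold lower number from compound 3 to compound 4 (0.30 log units; that floor lies within the scatter). For compound 4 the estimated value is 5000 nM, with an expected range of 1800 nM to 14000 nM.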

Compound 4, half-maximal inhibitory concentration: 1670 nM
Compound 4: middle estimate off by 3.0-fold (0.48 log units), on the high side, outside the stated range (below it).
By their numbers in this assay, from the lowest: compound 2; then compounds 4 and 1 (each within the scatter of the next). At a limit, above all of these: compound 3.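

In this assay compound 3 stands at > 10000 nM, which is a limit of the assay and not a number. Turning 4-methylphenyl into 2-fluoro-4-methylphenyl on this core gives an at least 5.9-fold lower number from compound 3 to compound 4 (0.77 log units; beyond the scatter), so the change lowers the number here as it did on the core of compound 1. The fluoro that separates the two cores still goes with a higher number once the 2-fluoro-4-methylphenyl group is present, with a 2.1-fold higher number from compound 2 to compound 4 (0.32 log units; beyond the scatter).

Whether the change on the 4-methylphenyl group has the same size on both cores stays open because one of its starting values is a limit: the same change on two cores in this assay, a 3.0-fold lower number (0.48 log units; beyond the scatter) from compound 1 to compound 2 and an at least 5.9-fold lower number (0.77 log units; beyond the scatter) from compound 3 to compound 4; the limit leaves it open whether they differ The compounds shown also leave open how a chloro or a methoxy group on this same aromatic carbon would read.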